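The compounds below may be only part of what the source reports. "The series", "measured", "known", "first", "only" and "open" are said of these compounds alone.

Compound 2 `c1ccc(Cc2nnc(-c3c[nH]c4ccccc34)o2)cc1` stands, on the numbers available, only at a boundary. In a functional assay on PC-3 cells (Homo sapiens) for cytotoxicity, read by MTT assay (a lower number here means a stronger inhibitor, a higher number a weaker inhibitor), compound 2 gives > 1000000 nM, which is a limit of the assay rather than a number. Within the data shown here, the one neighbour, compound 1 `c1ccc(-c2nnc(-c3c[nH]c4ccccc34)o2)cc1`, is in the same position: in this assay compound 1 gives > 1000000 nM, again a limit. Among the measured compounds shown here, the only recorded step, a step that the two limits leave unreadable from compound 1 to compound 2, is therefore unreadable in size and direction, and the sole piece of evidence is the limit of > 1000000 nM in this assay, at which 2 of the 2 values shown sit.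

Compound 3 `c1ccc2c(-c3nnc(-c4ccncc4)o3)c[nH]c2c1` has not yet been measured. It differs from compound 2 by pyridin-4-yl in place of benzyl on an aromatic carbon. For the measured compounds named here, no measured step concerns an exchange of this kind; the single step on record, a step that the two limits leave unreadable from compound 1 to compound 2, bears on it only in so far as it shows that two members sit together at the limit. The step expected from compound 2 to compound 3 in this assay is accordingly none beyond the scatter, a number no higher from compound 2 to compound 3 (the limit leaves the size open). Compound 3 is estimated to give 1000000 nM in this assay, within a range from 300000 nM to 3000000 nM, with the assay most likely again reporting only a limit.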

Compound 3, half-maximal inhibitory concentration: 4100 nM
Compound 3: middle estimate off by 240-fold (2.39 log units), on the high side, outside the stated range (below it).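

The earlier compounds shown here showed only that phenyl and benzyl on this aromatic carbon leave the series at the limit, whereas compound 3 shows that the group here can move the number in this assay a long way. Pyridin-4-yl in place of benzyl gives a large change (an at least 240-fold lower number from compound 2 to compound 3 (2.38 log units; beyond the scatter)), and pyridin-4-yl in place of phenyl gives another (an at least 240-fold lower number from compound 1 to compound 3 (2.38 log units; beyond the scatter)), so both carbon-only rings stand apart from the ring with one nitrogen. Both steps are open-ended because their starting values are limits of the assay and not numbers: the limit of > 1000000 nM in this assay, at which 2 of the 3 values shown sit.

The compounds shown do not settle whether the step depends on the ring nitrogen alone or also on where it sits in the ring, which pyridin-3-yl and pyridin-2-yl groups on the same carbon would address. They also leave open how a phenyl ring carrying an amine or a methoxy group would stand here, and whether a second ring nitrogen, as in a pyrimidinyl group, would lower the number further.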